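The source may report more compounds than this note shows. Statements on the series, on what has been measured and on what is new or still open speak of the compounds shown alone.

In a functional assay for inhibition, with Homo sapiens as the target (on this read-out higher numbers stand for weaker inhibition and lower numbers for stronger inhibition), compound 1 `CC(O)c1cc(-c2ccccc2)c2ccc(OCc3cccc(C4(O)CCOCC4)c3)cc2c1` gives 28 nM, compound 2 `COCc1cc(-c2ccccc2)c2ccc(OCc3cccc(C4(O)CCOCC4)c3)cc2c1` gives 4 nM and compound 3 `O=C(O)c1cc(-c2ccccc2)c2ccc(OCc3cccc(C4(O)CCOCC4)c3)cc2c1` gives 190 nM, the highest number of the three and so the weakest inhibition. Compound 4 `Cn1nnnc1-c1cc(-c2ccccc2)c2ccc(OCc3cccc(C4(O)CCOCC4)c3)cc2c1` replaces the carboxy group of compound 3 with 1-methyl-1H-tetrazol-5-yl: 1-methyl-1H-tetrazol-5-yl in place of carboxy on an aromatic carbon. Two measured changes at the same aromatic carbon bear on this: a 6.8-fold higher number from compound 1 to compound 3 (0.83 log units; beyond the scatter), which is modest, and a 48-fold higher number from compound 2 to compound 3 (1.68 log units; beyond the scatter), which is large. Carboxy gave the higher number both times, but no ring has yet been measured at this place. A modest to large drop in this assay is therefore expected. Compound 4 is estimated at 20 nM, with a range from 5 nM to 80 nM. The estimated change is a 9.5-fold lower number from compound 3 to compound 4 (0.98 log units; beyond the scatter).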

Compound 4, half-maximal inhibitory concentration: > 67 nM
Compound 4 ended at the assay's limit; the forecaster's own chance of this, stated with the estimate: 2%; middle value at least 3.3-fold (0.52 log units) away from the limit.
By their numbers in this assay, from the lowest: compound 2; then compound 1; then compound 3.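

The result for compound 4 in this assay is a limit of the assay, not a number: the limit of > 67 nM in this assay, at which 1 of the 4 values shown sits. Even so, the limit shows that a first ring at this aromatic carbon does worse than either open chain, with an at least 16-fold higher number from compound 2 to compound 4 (1.22 log units; beyond the scatter) against methoxymethyl and an at least 2.3-fold higher number from compound 1 to compound 4 (0.37 log units; beyond the scatter) against 1-hydroxyethyl. The step from carboxy to the ring cannot be read, so these two groups cannot be ranked against each other.

Still open, on these data alone, is whether an aminomethyl group or a longer ether such as ethoxymethyl would match methoxymethyl here. As far as these compounds go, it is equally open whether an unmethylated tetrazole would behave like compound 4.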